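Fused-ring alkyne series: propanoyl to cyclopropylsulfonyl step

The source may report more compounds than this note shows. Statements on the series, on what has been measured and on what is new or still open speak of the compounds shown alone.

Measured so far in an assay on HEK293 cells for positive allosteric modulation of metabotropic glutamate receptor 5 (Homo sapiens), read by FLIPR, with a stated time of 1 h; on this read-out lower numbers stand for an effect already at smaller amounts and higher numbers for an effect only at larger amounts of compound:
Compound 1 `O=C1c2sc(C#Cc3ccccc3)nc2CN1C1CC1` gives > 10000 nM, a limit.
Compound 2 `CN1CCc2nc(C#Cc3cccc(F)c3)sc2C1` gives > 10000 nM, a limit.
Compound 3 `CCC(=O)N1CCc2nc(C#Cc3ccccc3)sc2C1` gives > 10000 nM, a limit.

Compound 3 therefore stands at the limit of this assay and not at a number, and the same holds for compound 1 and compound 2, as the limit of > 10000 nM in this assay, at which 3 of the 3 values shown sit, records. Among the measured compounds shown here, no pair of measured compounds differs in one place, so no measured step shows what any change does here. Compound 4 `O=S(=O)(C1CC1)N1CCc2nc(C#Cc3ccccc3)sc2C1` differs from compound 3 by cyclopropylsulfonyl in place of propanoyl on an amine nitrogen in a ring. With every measured value at the limit, no direction and no size beyond the scatter can be expected for the step that the limit leaves unreadable from compound 3 to compound 4; a limit is again expected. Compound 4 is accordingly estimated at 15000 nM, within a range from 4000 nM to 60000 nM.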

Compound 4, half-maximal effective concentration: > 10000 nM
Compound 4 gave a limit, no number; the forecaster's own chance of this, stated with the estimate: 80%; the middle value lies beyond the limit too.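

In this assay no step can be read from compound 3 to compound 4, as both values are limits. What any change on the shared core does to the read-out stays open, with every compound shown at the same limit: the limit of > 10000 nM in this assay, at which 4 of the 4 values shown sit.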